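From compound 2 to compound 3

This account rests on a few compounds, and the source may have more. Where it says the series, first, only, none or still open, it means among the compounds named here.

Measured in a functional assay on MCF-A cells (Homo sapiens) for cytotoxicity; a higher number here means a weaker inhibitor of growth, a lower number a stronger inhibitor of growth:
- compound 1 `COc1ccc(C2=C(c3cc(OC)c(OC)c(OC)c3)CC3CCCN3C2=O)cc1O`: > 100000 nM
- compound 2 `COc1ccc(C2=C(c3ccc(SC)cc3)CC3CCCN3C2=O)cc1O`: 5000 nM

The entry of compound 1, > 100000 nM, is a limit of the assay and not a number. Among the compounds with values here, compound 2, at 5000 nM, holds the only actual number in this assay, so the series offers no measured step to serve as a yardstick.

Compound 3 `COc1ccc(C2=C(c3ccc(SC)cc3)CC3CCCN3C2=O)cc1OC(=O)CNC(=O)OC(C)(C)C` is compound 2 altered at one place: (((tert-butoxycarbonyl)amino)methyl)carbonyl in place of hydrogen on an oxygen on an aromatic ring. (((tert-Butoxycarbonyl)amino)methyl)carbonyl stands in place of hydrogen on an oxygen on an aromatic ring. Within the data shown here, no measured pair tests this change. With compound 2 at 5000 nM as the only anchor, a modest move towards weaker growth inhibition is expected, and a result within the scatter would be no surprise. The estimated change is a 1.6-fold higher number from compound 2 to compound 3 (0.20 log units; within the scatter). Compound 3 is expected at 8000 nM, with an estimated range from 2000 nM to 35000 nM.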

Compound 3, concentration for 50% growth inhibition: 6000 nM
Compound 3: the middle estimate sits 1.3-fold (0.12 log units) above what was measured; the measured number falls inside the stated range.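

In this assay, this oxygen on an aromatic ring now has its first readable step: a 1.2-fold higher number from compound 2 to compound 3 (0.08 log units; within the scatter). Hydrogen on this oxygen can therefore give way to (((tert-butoxycarbonyl)amino)methyl)carbonyl, which adds a sizeable group with no ring and no net charge, with the change in number staying within the scatter. Nothing available bears on why the number holds after this change.

On these data alone, it remains open whether a free amine in place of the tert-butoxycarbonyl-protected nitrogen, a carboxylic acid or a longer chain on the same oxygen would read the same in this assay. As far as these compounds go, the entry of compound 1, > 100000 nM, is a limit, and whether the same change would alter it also remains open.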